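Piperidinyl Ether in Place of the Piperazine Arm

This account rests on a few compounds, and the source may have more. Where it says the series, first, only, none or still open, it means among the compounds named here.

Measured compounds:
compound 1 `Cc1cc(Cl)cc(-c2ccnc3cc(CN4C(=O)CCC4=O)sc23)c1CN1CCNC[C@@H]1C` — 280 nM
compound 2 `Cc1cc(Cl)cc(-c2ccnc3cc(CN4C(=O)C5CC5C4=O)sc23)c1C[C@@H]1CNC[C@@H](C)O1` — 60 nM
compound 3 `Cc1cc(Cl)cc(-c2ccnc3cc(CN4C(=O)C5CC5C4=O)sc23)c1C[C@H]1OCCN[C@@H]1C` — 210 nM

In an assay on RKO cells for inhibition of ubiquitin carboxyl-terminal hydrolase 7 (Homo sapiens), read by a luciferase reporter, with a stated time of 18 h (on this read-out higher numbers stand for an effect only at larger amounts of compound and lower numbers for an effect already at smaller amounts), compound 1 gives 280 nM, the highest number of the three shown; compound 3 lies within the scatter of it, while compound 2 lies beyond the scatter below it. Compound 4 `Cc1cc(Cl)cc(-c2ccnc3cc(CN4C(=O)CCC4=O)sc23)c1O[C@@H]1CCNC[C@@H]1C` differs from compound 1 in one place: (3-methylpiperidin-4-yl)oxy in place of (2-methylpiperazin-1-yl)methyl on an aromatic carbon. Within the data shown here, the only measured step, a 3.5-fold higher number from compound 2 to compound 3 (0.54 log units; beyond the scatter), moves a methyl group on a morpholine ring and does not touch the arm exchanged here, so no measured step bears directly on this change. With nothing to anchor a direction, compound 4 is expected to stay close to compound 1, with an expected step of a 1.1-fold lower number from compound 1 to compound 4 (0.05 log units; within the scatter). Compound 4 is estimated at 250 nM, within a range of 80 nM to 800 nM.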

Compound 4, half-maximal effective concentration: 150 nM
Compound 4: the middle estimate sits 1.7-fold (0.22 log units) above what was measured; the measured number falls inside the stated range.
By their numbers in this assay, from the lowest: compound 2; then compounds 4, 3 and 1 (each within the scatter of the next).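

In this assay, putting (3-methylpiperidin-4-yl)oxy in place of (2-methylpiperazin-1-yl)methyl on this aromatic carbon gives a 1.9-fold lower number from compound 1 to compound 4 (0.27 log units; within the scatter) and so leaves the two arms indistinguishable. This is the first step shown at this position, and it shows that the arm can lose one ring hetero atom and gain a second defined stereocentre with no change beyond the scatter. On these data alone, whether an open-chain arm such as a 2-(dimethylamino)ethoxy group would read the same on this carbon remains open. Nothing shown here gives a reason for this outcome.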